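The source may hold more compounds than are shown below. What is called first, only, known or untested is meant among the compounds shown, and "the series" means these compounds.

Among the measured compounds shown here, compound 2 `FC(F)(F)Oc1ccc(-c2ccc(-c3ccc(-c4nc5ccccc5[nH]4)cc3)cc2)cc1` gives 100000 nM in a functional assay on COLO 205 cells (Homo sapiens) for inhibition, read by sulforhodamine B assay (a lower number here means a stronger inhibitor of growth, a higher number a weaker inhibitor of growth), the highest of the two numbers so far. For the measured compounds named here, compound 1 `FC(F)(F)c1ccc(-c2ccc(-c3ccc(-c4nc5ccccc5[nH]4)cc3)cc2)cc1` gives 33900 nM, and the one measured step runs a 2.9-fold higher number from compound 1 to compound 2 (0.47 log units; beyond the scatter). Compound 3 `Oc1ccc(-c2ccc(-c3ccc(-c4nc5ccccc5[nH]4)cc3)cc2)cc1` differs from compound 2 by hydrogen in place of trifluoromethyl on an oxygen on an aromatic ring. Going by the values given here, no measured compound carries a hydroxy group, so that single step is the only guide, and it was modest. Compound 3 is therefore expected to remain a weak inhibitor of growth, with 80000 nM in this assay, within 25000 nM to 250000 nM. For compound 3 the expected change is a 1.3-fold lower number from compound 2 to compound 3 (0.10 log units; within the scatter), likely within the scatter.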

Compound 3, concentration for 50% growth inhibition: 100000 nM
The estimate for compound 3 lay 1.3-fold (0.10 log units) below the measured number; the measured number falls inside the stated range.
By their numbers in this assay, from the lowest: compound 1; then compounds 2 and 3 (each within the scatter of the next).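

In this assay, replacing trifluoromethyl on the oxygen with hydrogen gives no change at the digits printed from compound 2 to compound 3 (within the scatter), so removing that group leaves the number unchanged. Placing hydroxy instead of trifluoromethyl on the aromatic carbon gives a 2.9-fold higher number from compound 1 to compound 3 (0.47 log units; beyond the scatter), which matches the earlier step to trifluoromethoxy and leaves compound 1 with the lowest number of the three. No supporting measurement is available to explain these results.

From the compounds shown here alone, it remains open how an amine, a carboxylic acid or a longer chain on this aromatic carbon would compare with compound 1.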